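This account rests on a few compounds, and the source may have more. Where it says the series, first, only, none or still open, it means among the compounds named here.

Series notes on the cytotoxicity read-out.

Compound 1 `CCOC(=O)c1c(-c2cc(F)cc(OC)c2)[nH]c2cc(OC)ccc2c1=O` is the reference point. In an ADME assay on BJ cells (Homo sapiens) for cytotoxicity, read by luminescence, with a stated time of 72 h (on this read-out higher numbers stand for an effect only at larger amounts of compound and lower numbers for an effect already at smaller amounts), compound 1 gives > 21500 nM, which is a limit of the assay and not a measured number. For the measured compounds named here, the only measured neighbour is compound 2 `CCOC(=O)c1c(-c2cccc(OCC)c2)[nH]c2cc(OC)ccc2c1=O`. In this assay compound 2 likewise gives > 21500 nM, again only a limit. Going by the values given here, the one recorded step, a step that the two limits leave unreadable from compound 1 to compound 2, therefore cannot be sized; all that is known is the limit of > 21500 nM in this assay, at which 2 of the 2 values shown sit, so compound 1 stands at the limit together with the single other value shown.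

Compound 3 `CCOC(=O)c1c(-c2cc(F)cc(OC)c2)[nH]c2cc(OC)c(F)cc2c1=O` is not yet measured. It differs from compound 1 by fluoro in place of hydrogen on an aromatic carbon. No measured step bears on this change; the one step shown is unreadable, and it concerns a different part of the structure.

Given that compound 1 sits at the limit > 21500 nM and no step argues for a move beyond the scatter, a step that the limit leaves unreadable from compound 1 to compound 3 is expected, in no clear direction. Compound 3 is thus estimated at 30000 nM, with a range of 12000 nM to 90000 nM, and most likely it will again be reported only as a limit.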

Compound 3, half-maximal effective concentration: > 21500 nM
Compound 3 gave a limit, no number; the forecaster's own chance of this, stated with the estimate: 80%; the middle value lies beyond the limit too.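

No new step can be read from compound 1 to compound 3 in this assay, as both compounds give only limits of the assay: the limit of > 21500 nM in this assay, at which 3 of the 3 values shown sit.

The compounds shown leave open at what concentration any of them reaches a half-maximal effect on this read-out, and whether either the fluoro or the 3-ethoxyphenyl change alters it.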